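The compounds below may be only part of what the source reports. "The series", "measured", "known", "first", "only" and "open" are said of these compounds alone.

Of the compounds shown here, two have been tested in a functional assay on HeLa cells (Homo sapiens) for inhibition, read by MTT assay; a lower number here means a stronger inhibitor, a higher number a weaker inhibitor. Compound 1 `CCCCCCCCn1cc(/C=C/C(=O)c2ccc(NC(=O)CN3CCN(c4ccccc4F)CC3)cc2)nn1` gives 33800 nM, and compound 2 `CCCCCCCCCCn1cc(/C=C/C(=O)c2ccc(NC(=O)CN3CCN(c4ccccc4F)CC3)cc2)nn1` gives 47800 nM. For the measured compounds named here, compound 1 therefore carries the lower of the two numbers, but the only measured step, a 1.4-fold higher number from compound 1 to compound 2 (0.15 log units; within the scatter), is within the scatter, so the two cannot be ordered.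

The next compound, compound 3 `CCCCCCCCn1cc(/C=C/C(=O)c2ccc(NC(=O)CN3CCN(C(=O)OC(C)(C)C)CC3)cc2)nn1`, differs from compound 1 in a different part of the molecule: tert-butoxycarbonyl in place of 2-fluorophenyl on an amine nitrogen in a ring. Going by the values given here, the one measured step concerns the saturated chain on the aromatic nitrogen and says nothing about the amine nitrogen in the ring where compound 3 changes, so no measured step bears on the step from compound 1 to compound 3, and the direction cannot be read from the data.

With no guidance on this position, compound 3 is expected to stay near compound 1, and the step of a 1.2-fold higher number from compound 1 to compound 3 (0.07 log units; within the scatter) is estimated to remain within the scatter. In this assay compound 3 is thus estimated at 40000 nM, with a wide range from 10000 nM to 160000 nM.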

Compound 3, half-maximal inhibitory concentration: 32100 nM
Compound 3: the middle estimate sits 1.2-fold (0.10 log units) above what was measured, and the stated range covers the measured number.
By their numbers in this assay, from the lowest: compounds 3, 1 and 2 (each within the scatter of the next).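

In this assay, putting tert-butoxycarbonyl in place of 2-fluorophenyl on the amine nitrogen in the ring gives a 1.1-fold lower number from compound 1 to compound 3 (0.02 log units; within the scatter), so this change does not separate the two compounds. For the compounds shown here, this is the first reading at this position, and it shows that a group with a six-membered aromatic ring of carbon only and a group with no ring, a double bond outside aromatic rings and hydrogen-bond acceptors, both of the same heavy-atom count, give numbers that cannot be told apart in this assay. No supporting measurement is available to explain this result.

The compounds shown leave open whether the number at this amine nitrogen would move with a quite different substituent, such as a plain hydrogen, a methyl, a benzyl or a carboxylic acid-bearing chain, since both groups seen so far fall within the scatter of each other. They also leave open whether tert-butoxycarbonyl would behave the same way alongside the longer chain of compound 2, as the two sites have been varied only one at a time.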